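Aryl swap on the shared core: cytotoxicity notes

This account rests on a few compounds, and the source may have more. Where it says the series, first, only, none or still open, it means among the compounds named here.

Going by the values given here, compound 2 `Cn1nc(-c2nnc(-c3ccccc3Br)o2)c2ccccc21` is the only member with a number in an ADME assay on L02 cells (Homo sapiens) for cytotoxicity, read by MTT assay, with a stated time of 72 h (on this read-out lower numbers stand for stronger inhibition and higher numbers for weaker inhibition), where compound 2 gives 89000 nM. Compound 1 `Cn1nc(-c2nnc(-c3cccc(Cl)c3)o2)c2ccccc21` gives > 100000 nM, which is a limit of the assay (the limit of > 100000 nM in this assay, at which 1 of the 2 values shown sits). Among the compounds with values here, the single measured step, an at least 1.1-fold lower number from compound 1 to compound 2 (0.05 log units; that floor lies within the scatter), also exchanges the aryl group at this same place. Compound 3 `Cc1cccc(-c2nnc(-c3nn(C)c4ccccc34)o2)c1` carries 3-methylphenyl in place of 2-bromophenyl on an aromatic carbon. Within the data shown here, since the only comparable step sits inside the scatter, no step beyond the scatter is expected in a 1.1-fold higher number from compound 2 to compound 3 (0.03 log units; within the scatter). Compound 3 is therefore estimated at 95000 nM, ranging from 45000 nM to 200000 nM, with a real chance that only a limit is reported.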

Compound 3, half-maximal inhibitory concentration: > 100000 nM
Compound 3 ended at the assay's limit; the forecaster's own chance of this, stated with the estimate: 50%; at least 1.0-fold (0.02 log units) between middle value and limit.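

In this assay, the exchange at this aromatic carbon gives an at least 1.1-fold higher number from compound 2 to compound 3 (0.05 log units; that floor lies within the scatter), so a ring without halogen shows no step beyond the scatter from the 2-bromophenyl of the earlier member. The step between compound 1 and compound 3, methyl in place of chloro, cannot be read, since both values are limits. The 3-methylphenyl of compound 3 thus joins the 3-chlorophenyl of compound 1 at the limit: the limit of > 100000 nM in this assay, at which 2 of the 3 values shown sit.

Going by these compounds, with a number for compound 2 alone, the true size of any step at this position stays unknown. On these data alone, whether an amine or a carboxylic acid on the aryl ring would give a clear number remains open.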